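From compound 2 to compound 3: one added fluoro

A few compounds are considered here, and "the series" means these few. Any claim that something is new, unique, unknown or untested is made for them only; others in the source may bear on it.

Measured in an ADME assay on Raji cells (Homo sapiens) for cytotoxicity, with a stated time of 72 h; a lower number here means that less compound is needed, a higher number that more compound is needed for the effect:
- compound 1 `O=C(Nc1ccc(F)c(-c2nc3ccccc3s2)c1)c1cc([N+](=O)[O-])ccc1Cl`: > 25000 nM, a limit
- compound 2 `O=C(Nc1cccc(-c2nc3ccccc3s2)c1)c1cc([N+](=O)[O-])ccc1Cl`: > 27000 nM, a limit

Compound 2 stands at > 27000 nM, a limit and not a number. Compound 3 `O=C(Nc1cc(-c2nc3ccccc3s2)ccc1F)c1cc([N+](=O)[O-])ccc1Cl` differs from it by one change: fluoro in place of hydrogen on an aromatic carbon. Among the compounds with values here, the one measured step that bears on this also exchanges fluoro and hydrogen on an aromatic carbon: a step that the two limits leave unreadable from compound 1 to compound 2. Its size cannot be read, so it offers no direction and no magnitude to carry over. No step beyond the scatter is therefore expected in this assay, and the result for compound 3 is likely to be reported as a limit too. The expected step is a number no higher from compound 2 to compound 3 (the limit leaves the size open). For compound 3 the estimate is 27000 nM, within an expected range from 12000 nM to 60000 nM.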

Compound 3, half-maximal effective concentration: > 25000 nM
Compound 3: a limit, no number; the forecaster's own chance of this, stated with the estimate: 85%; the middle value lies beyond the limit too.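

No step can be read between compound 2 and compound 3: in this assay both results are limits and not numbers. The compounds shown leave open what concentration any of them needs for the effect, and whether fluoro in place of hydrogen changes it at all.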